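This account rests on a few compounds, and the source may have more. Where it says the series, first, only, none or still open, it means among the compounds named here.

Measured so far in a functional assay on 1A9 cells (Homo sapiens) for antiproliferative activity, read by sulforhodamine B assay, with a stated time of 3 days; a higher number here means that more compound is needed for the effect, a lower number that less compound is needed: compound 1 `CCCC1=C(OC)C(CCC)(CCC)C(=O)/C(=C(O)\C=C\c2ccccc2)C1=O` gives 3.7 uM; compound 2 `CCCC1=C(OC)C(CCC)(CCC)C(=O)/C(=C(O)\C=C\c2ccc(I)cc2)C1=O` gives 1.8 uM; compound 3 `CCCC1=C(OCCC(C)C)C(CCC)(CCC)C(=O)/C(=C(O)\C=C\c2ccccc2)C1=O` has no number, its entry in this assay reading "not determined" (no result reported).

Compound 3 therefore stands nowhere on the numbers: its value is not known. Compound 4 `CCCC1=C(OCC(C)C)C(CCC)(CCC)C(=O)/C(=C(O)\C=C\c2ccccc2)C1=O` differs from compound 3 by isopropyl in place of isobutyl on a saturated chain carbon bound to an oxygen on an unsaturated carbon. Going by the values given here, the one measured step, a 2.1-fold lower number from compound 1 to compound 2 (0.31 log units; beyond the scatter), concerns iodo in place of hydrogen on the aromatic ring and does not touch the group on the oxygen on the unsaturated carbon, so it says nothing about this change. Compound 1 differs from compound 4 only in that group, and its value is the nearest anchor. Among the compounds with values here, compound 4 is expected near 3.5 uM, with a range of 1 uM to 12 uM; the uncertainty is wide, since no step on this oxygen-bound group has been measured.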

Compound 4, concentration for half-maximal effect: 6.9 uM
Compound 4: middle estimate off by 2.0-fold (0.29 log units), on the low side; the measured number falls inside the stated range.
By their numbers in this assay, from the lowest: compound 2; then compounds 1 and 4 (each within the scatter of the next).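

Read in this assay, the first measured change to the group on the oxygen on an unsaturated carbon is a 1.9-fold higher number from compound 1 to compound 4 (0.27 log units; within the scatter), so the isobutoxy group of compound 4 leaves the number within the scatter of compound 1. This position therefore accepts a branched chain without a change that can be read. No measurement available here explains this result.

As far as these compounds go, the step between compound 3 and compound 4 cannot be read, as compound 3 has no number, so the effect of the isopentyloxy chain remains unknown. Also open, from the compounds shown here alone, are a terminal amine or carboxylic acid on this chain and whether the iodo group combines with isobutoxy.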